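Removing the amino-acid arm from a quinone cytotoxicity series

A few compounds are considered here, and "the series" means these few. Any claim that something is new, unique, unknown or untested is made for them only; others in the source may bear on it.

Compound 1 `CC(C)(C)C1=CC(=O)C=C(NCC(=O)O)C1=O`: 171000 nM
Compound 2 `CC(C)[C@@H](NC1=CC(=O)C=C(C(C)(C)C)C1=O)C(=O)O`: 133000 nM
Compound 3 `CC(C)C[C@H](NC1=CC(=O)C=C(C(C)(C)C)C1=O)C(=O)O`: 84900 nM

Three quinones have been measured in a functional assay on MDA-MB-453 cells (Homo sapiens) for cytotoxicity, read by MTT assay, with a stated time of 72 h; on this read-out higher numbers stand for weaker inhibition and lower numbers for stronger inhibition. Compound 1 gives the highest number of the three, although the step of a 1.3-fold lower number from compound 1 to compound 2 (0.11 log units; within the scatter) and the step of a 2.0-fold lower number from compound 1 to compound 3 (0.30 log units; within the scatter) are both within the scatter, so the three numbers cannot be ordered.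

Compound 4 `CC(C)(C)C1=CC(=O)C=CC1=O` is the core of compound 1 with the whole side arm taken away: hydrogen in place of (carboxymethyl)amino on a double-bonded ring carbon. The two measured steps both alter the saturated chain carbon inside that arm, one putting isopropyl and the other isobutyl in place of hydrogen, and neither moved the number beyond the scatter. Among the measured compounds shown here, neither step touches the loss of the (carboxymethyl)amino group itself, so no measured step bears directly on the change to compound 4. For the measured compounds named here, the only guide is that the three measured numbers all sit close together and that the change is larger than either measured step. Compound 4 is therefore expected to move by a 2.9-fold lower number from compound 1 to compound 4 (0.45 log units; beyond the scatter), and its number in this assay is estimated at 60000 nM, with a wide range from 10000 nM to 300000 nM.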

Compound 4, half-maximal inhibitory concentration: 56800 nM
Estimate against measurement, compound 4: 1.1-fold (0.02 log units) above; the measured number falls inside the stated range.
By their numbers in this assay, from the lowest: compounds 4, 3, 2 and 1 (each within the scatter of the next, the first and the last beyond it).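

In this assay, among the compounds shown here, the step of a 3.0-fold lower number from compound 1 to compound 4 (0.48 log units; beyond the scatter) is the first one measured at the double-bonded ring carbon itself, where hydrogen replaces the whole (carboxymethyl)amino group, and the first step from compound 1 that lies beyond the scatter. The earlier steps shown here altered only a saturated chain carbon inside the arm, whereas this one shows that the arm can be removed entirely from this position, two ring bonds from the ring atom that bears a tert-butyl group, without the number rising; the step is modest and runs towards stronger inhibition. Nothing available explains why the number falls on this change.

The step removes the amine nitrogen and the carboxylic acid together, so the compounds shown cannot say which part of the arm accounts for it, and a plain amine or a methyl group at this ring carbon would be needed to separate them. They also leave open whether a longer chain ending in a carboxylic acid, or an ester in place of that acid, would behave like compound 1 or like compound 4.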